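Swapping one fluorophenyl for another on compound 2

The compounds below may be only part of what the source reports. "The series", "measured", "known", "first", "only" and "open" are said of these compounds alone.

Compound 1 `O=C(NCCCCc1ccccc1)c1cccc(C2SCC(=O)N2c2ccc(-c3ccccc3)cc2)c1`: > 1000 nM (a limit)
Compound 2 `O=C(NCCCCc1ccccc1)c1cccc(C2SCC(=O)N2c2cccc(F)c2)c1`: 32.4 nM

For the measured compounds named here, in a functional assay on HOS-TE85 cells (Homo sapiens) for inhibition, read by CCK-8 assay, with a stated time of 72 h (a lower number here means a stronger inhibitor, a higher number a weaker inhibitor), compound 2 gives 32.4 nM, the only exact number so far. For compound 1, > 1000 nM is a limit of the assay. Compound 3 `O=C(NCCCCc1ccccc1)c1cccc(C2SCC(=O)N2c2ccccc2F)c1` differs from compound 2 by 2-fluorophenyl in place of 3-fluorophenyl on an amide-type nitrogen in a ring. Going by the values given here, the one measured step, an at least 30-fold lower number from compound 1 to compound 2 (1.48 log units; beyond the scatter), is large, but it exchanged a very different group, and no measured step swaps one fluorophenyl for another. It therefore offers only weak guidance, and no step beyond the scatter is expected. The expected change is a 1.2-fold higher number from compound 2 to compound 3 (0.09 log units; within the scatter). Compound 3 is estimated at 40 nM, within a range of 10 nM to 200 nM.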

Compound 3, half-maximal inhibitory concentration: 34.1 nM
The estimate for compound 3 lay 1.2-fold (0.07 log units) above the measured number, and the stated range covers the measured number.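

In this assay, 2-fluorophenyl and 3-fluorophenyl on the amide-type nitrogen in the ring cannot be told apart, with a 1.1-fold higher number from compound 2 to compound 3 (0.02 log units; within the scatter). A second fluorophenyl also stands far from 4-phenylphenyl, with an at least 29-fold lower number from compound 1 to compound 3 (1.46 log units; beyond the scatter), so the large step is not peculiar to 3-fluorophenyl. Going by these compounds, the true size of that step stays open, since compound 1 is held at a limit: the limit of > 1000 nM in this assay, at which 1 of the 3 values shown sits. Still open, on these data alone, is whether the fluorine matters at all, as plain phenyl would show. As far as these compounds go, it is also open how 4-fluorophenyl, or a phenyl carrying an amine or a carboxylic acid, would compare.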